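A few compounds are considered here, and "the series" means these few. Any claim that something is new, unique, unknown or untested is made for them only; others in the source may bear on it.

Values in a physicochemical assay for solubility; a higher number here means a more soluble compound, a lower number a less soluble compound:
- compound 1 `C[C@H](Oc1ccc(S(C)(=O)=O)cc1C(=O)N1Cc2cc(C(F)(F)F)cnc2C1)C(F)(F)F`: 280 ug/mL
- compound 2 `CC(C)COc1ccc(S(C)(=O)=O)cc1C(=O)N1Cc2cc(C(F)(F)F)cnc2C1`: 445 ug/mL
- compound 3 `CS(=O)(=O)c1ccc(OCCC(F)(F)F)c(C(=O)N2Cc3cc(C(F)(F)F)cnc3C2)c1`: 513 ug/mL

Compound 3 does not separate from the other two, with a 1.8-fold higher number from compound 1 to compound 3 (0.26 log units; within the scatter) and a 1.2-fold higher number from compound 2 to compound 3 (0.06 log units; within the scatter). Next is compound 4 `CS(=O)(=O)c1ccc(-c2ccc(F)c(F)c2)c(C(=O)N2Cc3cc(C(F)(F)F)cnc3C2)c1`, with this change: 3,4-difluorophenyl in place of 3,3,3-trifluoropropoxy on an aromatic carbon. The new group sits para to a methylsulfonyl group.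

The measured steps, including a 1.6-fold higher number from compound 1 to compound 2 (0.20 log units; within the scatter), only exchange one chain on oxygen for another. None places an aromatic ring there, so they give no size for this change. A drop beyond the scatter is expected, but this is judgement alone and the range stays wide.

The estimated value for compound 4 is 130 ug/mL, within 30 ug/mL to 400 ug/mL. This estimate means an expected 3.9-fold lower number from compound 3 to compound 4 (0.60 log units; beyond the scatter).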

Compound 4, solubility: 42 ug/mL
Estimate against measurement, compound 4: 3.1-fold (0.49 log units) above; measured number inside the range.
By their numbers in this assay, from the lowest: compound 4; then compounds 1, 2 and 3 (each within the scatter of the next).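

In this assay a 3,4-difluorophenyl on this aromatic carbon, para to a methylsulfonyl group, gives steps beyond the scatter from all three chains on oxygen (a 12-fold lower number from compound 3 to compound 4 (1.09 log units; beyond the scatter)) (an 11-fold lower number from compound 2 to compound 4 (1.03 log units; beyond the scatter)) (a 6.7-fold lower number from compound 1 to compound 4 (0.82 log units; beyond the scatter)), whereas exchanges among those chains stayed within it. The loss therefore holds from each of the oxygen-linked groups shown, not from one alone. No measurement shown bears on the cause of this loss.

Open, as far as these compounds go, is whether the two fluorines take part, which a phenyl without fluorine would test. Also open, from the compounds shown here alone, is how a saturated amine on this aromatic carbon would compare.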